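Swapping Two Ring Stereocentres in a Peroxide Acid

This account rests on a few compounds, and the source may have more. Where it says the series, first, only, none or still open, it means among the compounds named here.

Compound 1 `C=C1CCCC(C)(C)C1CC[C@]1(C)CC[C@@H]([C@@H](C)C(=O)O)OO1` is a carboxylic acid built on a peroxide-containing core. In a functional assay on BT-549 cells (Homo sapiens) for inhibition (a higher number here means a weaker inhibitor of growth, a lower number a stronger inhibitor of growth), compound 1 gives > 10000 nM, which is a limit of the assay rather than a measured number (the limit of > 10000 nM in this assay, at which 1 of the 2 values shown sits). Compound 2 `C=C1CCCC(C)(C)C1CC[C@]1(C)CC[C@H]([C@@H](C)C(=O)OC)OO1` carries the methyl ester of the same acid; in this assay compound 2 gives 4950 nM. Compound 3 `C=C1CCCC(C)(C)C1CC[C@@]1(C)CC[C@H]([C@@H](C)C(=O)O)OO1` has not yet been measured. It differs from compound 1 only in how the ring is drawn: the two compounds have the same atoms and bonds; at least one stereo element is drawn with a configuration in one of them and without one in the other: 2 of 4 stereo elements differ; a stereocentre at a saturated ring carbon is drawn R in compound 1 and S in compound 3; a stereocentre at a saturated ring carbon is drawn S in compound 1 and R in compound 3. Among the compounds with values here, no measured pair shows how swapping these two ring stereocentres moves the read-out, and the starting point for compound 1 is only a limit. The expectation is therefore that compound 3 stays near that limit, so the step of a number no higher from compound 1 to compound 3 (the limit leaves the size open) is expected to be small, no larger than the usual scatter in either direction. Compound 3 is estimated at 10000 nM, within a range from 4000 nM to 25000 nM. A clearly stronger result for compound 3 would be the first sign that the drawn configuration of the ring matters in this assay.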

Compound 3, concentration for 50% growth inhibition: 1050 nM
The estimate for compound 3 lay 9.5-fold (0.98 log units) above the measured number, outside the stated range (below it).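

In this assay, the atoms and bonds stay the same and only the two ring stereocentres change, yet the result is an at least 9.5-fold lower number from compound 1 to compound 3 (0.97 log units; beyond the scatter). Within the data shown here, this is the first measured sign that the drawn configuration of the ring matters for this carboxylic acid, although a single pair of compounds cannot establish a wider rule. Two cautions apply to the size and meaning of this step, and the first is that the value of > 10000 nM for compound 1 is a limit of the assay: the limit of > 10000 nM in this assay, at which 1 of the 3 values shown sits. The second concerns how the structures are drawn: the fact that one of compounds 1 and 3 is drawn with a defined configuration and the other without, at the place where they differ

The two stereocentres change together, so the compounds shown leave open whether one of them alone accounts for the step or whether both are needed. From the compounds shown here alone, it is also open how the configuration of compound 3 behaves when the carboxylic acid is replaced by another group, such as a primary amide or an ethyl ester, and whether the read-out then follows the same direction as in this pair.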